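A few compounds are considered here, and "the series" means these few. Any claim that something is new, unique, unknown or untested is made for them only; others in the source may bear on it.

Measured compounds in an in vitro functional assay on cells for agonist activity at Bombesin receptor subtype-3 (Homo sapiens), read by luminescence and calcium flux; on this read-out higher numbers stand for an effect only at larger amounts of compound and lower numbers for an effect already at smaller amounts:
- compound 1, `CCCCc1cnc(C(CCCC)Cc2ccc(-c3ccccc3C(=O)O)cc2)[nH]1`, gives 2660 nM
- compound 2, `O=C(O)c1ccccc1-c1ccc(CCc2ncc(-c3ccccc3)[nH]2)cc1`, gives 4950 nM
- compound 3, `CCCCc1cnc(C(C)Cc2ccc(-c3ccccc3C(=O)O)cc2)[nH]1`, gives 2760 nM

Compound 2 has the highest of the three numbers, but its gaps to compound 3 and to compound 1 are both within the scatter, so the three compounds stand together on this read-out. Among the measured compounds shown here, the one step between measured compounds, a 1.0-fold higher number from compound 1 to compound 3 (0.02 log units; within the scatter), concerns a saturated chain carbon and shows no movement beyond the scatter.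

Compound 4, `O=C(O)c1ccccc1-c1ccc(CCc2ncc(Cc3ccccc3Cl)[nH]2)cc1`, differs from compound 2 in one place: 2-chlorobenzyl in place of phenyl on an aromatic carbon. For the measured compounds named here, no measured step touches this aromatic carbon, so the step from compound 2 to compound 4 has no direct precedent. Going by the values given here, the only guide is that all three measured compounds sit in the same range whatever group occupies the aromatic carbon or the chain carbon. The expectation is therefore a step of a 1.4-fold lower number from compound 2 to compound 4 (0.15 log units; within the scatter), without a confident direction, and a wide range.

Compound 4 is estimated at 3500 nM, between 800 nM and 15000 nM in this assay.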

Compound 4, half-maximal effective concentration: 292 nM
Compound 4: the middle estimate sits 12-fold (1.08 log units) above what was measured; the measured number lies below the stated range.
By their numbers in this assay, from the lowest: compound 4; then compounds 1, 3 and 2 (each within the scatter of the next).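

In this assay, the aromatic carbon of the five-membered aromatic ring responds strongly to its substituent: 2-chlorobenzyl in place of phenyl gives a 17-fold lower number from compound 2 to compound 4 (1.23 log units; beyond the scatter). This is the only step shown that lies beyond the scatter, whereas the change on the saturated chain carbon, a 1.0-fold higher number from compound 1 to compound 3 (0.02 log units; within the scatter), stays within it. Nothing available bears on the reason for the size of this step.

On these data alone, the step swaps phenyl for a group that differs in both chlorine and the added benzyl carbon, so the share of each stays open; plain benzyl and 2-chlorophenyl on this carbon would separate the two. Also open, as far as these compounds go, is how the response depends on the group's substitution, as with 4-chlorobenzyl, or with an amine on the benzyl ring.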